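Replacing a benzylamine with a piperidine on the shared core

The compounds below may be only part of what the source reports. "The series", "measured", "known", "first", "only" and "open" are said of these compounds alone.

Three compounds share one core and differ only in the group attached next to the ring nitrogen. Compound 1 `CC1CCC(Nc2nc(C(F)(F)F)ccc2CNC(=O)C(C)c2ccc(NS(C)(=O)=O)c(F)c2)CC1` gives 1130 nM in a functional assay on CHO-K1 cells for antagonist activity at transient receptor potential cation channel subfamily V member 1 (Homo sapiens), read by FLIPR; on this read-out lower numbers stand for stronger inhibition and higher numbers for weaker inhibition. Compound 2 `CC(C(=O)NCc1ccc(C(F)(F)F)nc1NCc1ccc(Cl)cc1)c1ccc(NS(C)(=O)=O)c(F)c1` gives 414 nM, the second highest of the three numbers, and compound 3 `CC(C(=O)NCc1ccc(C(F)(F)F)nc1N1CCC(Cc2ccc(F)c(F)c2)CC1)c1ccc(NS(C)(=O)=O)c(F)c1` gives 30 nM, the lowest. Among the compounds with values here, the one step between neighbours, a 2.7-fold lower number from compound 1 to compound 2 (0.44 log units; beyond the scatter), is modest and beyond the scatter.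

Compound 4 `CC(C(=O)NCc1ccc(C(F)(F)F)nc1N1CCC(CN(C)C)CC1)c1ccc(NS(C)(=O)=O)c(F)c1` is not yet measured. It differs from compound 2 by 4-((dimethylamino)methyl)piperidin-1-yl in place of (4-chlorobenzyl)amino on an aromatic carbon. Within the data shown here, no measured step exchanges the (4-chlorobenzyl)amino group for a piperidine ring, so the step from compound 1 to compound 2 does not bear directly on it. Compound 3, which also carries a piperidin-1-yl group but with a different substituent, gives a far lower number than compound 2. On this basis a modest step toward a lower number is expected, a 1.4-fold lower number from compound 2 to compound 4 (0.14 log units; within the scatter), with wide uncertainty. The estimate for compound 4 in this assay is 300 nM, within 50 nM to 1800 nM.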

Compound 4, half-maximal inhibitory concentration: 426 nM
Compound 4: middle estimate off by 1.4-fold (0.15 log units), on the low side; low and high end bracket the measured number.
By their numbers in this assay, from the lowest: compound 3; then compounds 2 and 4 (each within the scatter of the next); then compound 1.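

In this assay a piperidine ring in this place does not by itself give a low number: a 1.0-fold higher number from compound 2 to compound 4 (0.01 log units; within the scatter) is all that separates the 4-((dimethylamino)methyl)piperidin-1-yl group from the (4-chlorobenzyl)amino group, so these two cannot be told apart. The large difference lies further out on the piperidine, where a 14-fold higher number from compound 3 to compound 4 (1.15 log units; beyond the scatter) comes with dimethylamino in place of 3,4-difluorophenyl on the saturated chain carbon. Set against the (4-methylcyclohexyl)amino group, the same piperidine group shows a 2.7-fold lower number from compound 1 to compound 4 (0.42 log units; beyond the scatter) as a modest step.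

Nothing measured here gives a reason for these steps. The compounds shown leave open whether an unsubstituted phenyl ring or a hydroxyl group on that saturated chain carbon would give a number nearer that of compound 3 or that of compound 4.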